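A few compounds are considered here, and "the series" means these few. Any claim that something is new, unique, unknown or untested is made for them only; others in the source may bear on it.

Working notes on the series. In an ADME assay on Vero cells (Chlorocebus sabaeus) for inhibition (on this read-out higher numbers stand for lower toxicity in this test and lower numbers for higher toxicity in this test), compound 1 `COc1ccc(/C=C2\CCC/C(=C\c3cccc(OC)c3OC)C2=O)cc1` reads 401000 nM while compound 2 `COc1cccc(/C=C2\CCC/C(=C\c3ccccc3)C2=O)c1OC` reads 33500 nM and compound 3 `COc1cccc(/C=C2\CCC/C(=C\c3ccc(F)cc3)C2=O)c1OC` reads 33200 nM as measured. Compound 3 thus sits level with compound 2 and well under compound 1.

The next change leads to compound 4 `COc1cccc(/C=C2\CCC/C(=C\c3c(Cl)cccc3Cl)C2=O)c1OC` and is still unmeasured. It is 2,6-dichlorophenyl in place of 4-fluorophenyl on a double-bonded chain carbon bound to a double-bonded ring carbon and reads as 2,6-dichlorophenyl in place of 4-fluorophenyl on a double-bonded chain carbon bound to a double-bonded ring carbon.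

Among the compounds with values here, three measured steps bear on this change. Fluoro in place of hydrogen gives a 1.0-fold lower number from compound 2 to compound 3 (0.00 log units; within the scatter) and so no real movement. Taking away a methoxy gives a 12-fold lower number from compound 1 to compound 2 (1.08 log units; beyond the scatter) and a 12-fold lower number from compound 1 to compound 3 (1.08 log units; beyond the scatter) in two large steps. Within the data shown here, no measured step brings in chlorine, so the evidence is only indirect. Like compound 3 at 33200 nM compound 4 carries no methoxy on the aromatic group that changes, so a repeat of the large steps is not expected. The expected step is a 1.2-fold higher number from compound 3 to compound 4 (0.08 log units; within the scatter) and thus none beyond the scatter, though the range is kept wide. For compound 4 the estimated value is 40000 nM within an expected range of 12000 nM to 120000 nM in this read-out.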

Compound 4, half-maximal cytotoxic concentration: 160000 nM
For compound 4 the middle estimate is 4.0-fold (0.60 log units) below the measured one; measured number above the stated range.
By their numbers in this assay, from the lowest: compounds 3 and 2 (each within the scatter of the next); then compound 4; then compound 1.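

In this assay, within the data shown here, the position on a double-bonded chain carbon bound to a double-bonded ring carbon proves responsive to a group without methoxy: 2,6-dichlorophenyl gives a 4.8-fold higher number from compound 3 to compound 4 (0.68 log units; beyond the scatter) and a 4.8-fold higher number from compound 2 to compound 4 (0.68 log units; beyond the scatter) in two modest steps beyond the scatter, whereas the only earlier halogen change gave a 1.0-fold lower number from compound 2 to compound 3 (0.00 log units; within the scatter) and no real movement. The methoxy-free groups therefore no longer read alike, and the number is no longer tied to the 4-methoxyphenyl group alone, although 2,6-dichlorophenyl still falls short of it, with a 2.5-fold lower number from compound 1 to compound 4 (0.40 log units; beyond the scatter) as a modest step beyond the scatter. No supporting measurement bears on why the number moves with this change.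

The compounds shown hold a single chlorinated group, so the presence of chlorine and its placement on the phenyl ring cannot be told apart here. Going by these compounds, how an aminophenyl group or a phenyl group carrying a carboxylic acid would read at this position stays open, as does whether any other group here can match or pass compound 1 in this read-out.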